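A few compounds are considered here, and "the series" means these few. Any claim that something is new, unique, unknown or untested is made for them only; others in the source may bear on it.

Three compounds have been measured in a functional assay on HCC 2998 cells (Homo sapiens) for inhibition, read by sulforhodamine B assay, with a stated time of 48 h, tested at 1 uM; on this read-out higher numbers stand for a weaker effect at the one concentration tested and lower numbers for a stronger effect:

compound 1, `O=C(Nc1cccc(-n2cc(-c3ccncc3)c(-c3cc(O)cc(Cl)c3)n2)c1)Nc1ccc(Cl)c(Cl)c1`, 96%;
compound 2, `COc1cc(Cl)cc(-c2nn(-c3cccc(NC(=O)Nc4ccc(Cl)c(C(F)(F)F)c4)c3)cc2-c2ccncc2)c1`, 97%;
compound 3, `COc1cc(Cl)cc(-c2nn(-c3cccc(NC(=O)Nc4cc(C(F)(F)F)cc(C(F)(F)F)c4)c3)cc2-c2ccncc2)c1`, 38%.

Compound 1 stands, together with compound 2, at the high end of these three numbers, which on this read-out means a weak effect at the single concentration tested. The number of compound 2 lies within the usual scatter of that of compound 1, so the two cannot be told apart. The furthest away is compound 3, whose number is far lower and beyond the scatter, so compound 3 shows the clearer effect of the three.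

Compound 4, `COc1cc(Cl)cc(-c2nn(-c3cccc(NC(=O)Nc4ccc(Cl)c(Cl)c4)c3)cc2-c2ccncc2)c1`, has not yet been measured in this assay. It differs from compound 1 in one place: methyl in place of hydrogen on an oxygen on an aromatic ring. Compounds 2 and 3 carry the same methoxy group as compound 4, and their numbers range from one close to that of compound 1 to one well below it, so the methoxy group alone does not settle the outcome. For the measured compounds named here, no measured pair isolates this exact exchange. The step from compound 1 to compound 4 is expected to be small, at most slightly downward, and within the scatter, as a number 6 percentage points lower from compound 1 to compound 4 (within the scatter). Compound 4 is estimated at 90%, with a range from 55% to 105%.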

Compound 4, a percentage reported as activity, at one concentration (the size of the read-out at that concentration, not a potency): 91%
Estimate against measurement, compound 4: 1 percentage points below; low and high end bracket the measured number.
By their numbers in this assay, from the lowest: compound 3; then compounds 4, 1 and 2 (each within the scatter of the next).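

In this assay, for the compounds shown here, the exchange of hydroxy for methoxy gives a number 5 percentage points lower from compound 1 to compound 4 (within the scatter) and so shows no change that this read-out can separate from ordinary scatter, which is the first direct reading of this position. A second exchange, chloro in place of trifluoromethyl on an aromatic carbon, gives a number 6 percentage points lower from compound 2 to compound 4 (within the scatter) and is likewise too small to count, so on this background neither place moves the number measurably at the single concentration tested. No other data are at hand that could explain these results.

What an amine, a carboxylic acid or a longer chain such as ethoxy would do on this oxygen remains open, since hydroxy and methoxy are the only two groups shown there. Also open, from the compounds shown here alone, is whether hydroxy and methoxy would read alike on the background of compound 3, which differs from each of the other compounds in more than one place, so that its steps cannot be read.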